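A Longer Fluorinated Arm on Compound 2

The compounds below may be only part of what the source reports. "The series", "measured", "known", "first", "only" and "open" are said of these compounds alone.

Three compounds share one core. Compound 1 `C[C@]1(c2ccc(O)cc2)CSc2cc(O)ccc2[C@H]1CCCCCCCCC(CCCC(F)(F)C(F)(F)F)C(=O)O` gives 41% in a functional assay on the whole organism for antagonist activity, with Mus musculus as the target, at a dose of 3 mg/kg by the oral route; a lower number here means a weaker effect, a higher number a stronger effect of the compound at the dose given; compound 2 `C[C@]1(c2ccc(O)cc2)CSc2cc(O)ccc2[C@H]1CCCCCCCCCC(CCCC(F)(F)C(F)(F)F)C(=O)O` gives 45%, and compound 3 `C[C@]1(c2ccc(O)cc2)CSc2cc(O)ccc2[C@H]1CCCCCCCCCC(CCCC(F)(F)C(F)(F)C(F)(F)C(F)(F)F)C(=O)O` gives 55%. Compound 2 stands between its two neighbours, each within the scatter of it. Compound 4 `C[C@]1(c2ccc(O)cc2)CSc2cc(O)ccc2[C@H]1CCCCCCCCCC(CCCCC(F)(F)C(F)(F)F)C(=O)O` differs from compound 2 in one place: 2,2,3,3,3-pentafluoropropyl in place of 1,1,2,2,2-pentafluoroethyl on a saturated chain carbon, four bonds along the chain from a carbonyl carbon. Within the data shown here, the only measured step at this chain position is a number 10 percentage points higher from compound 2 to compound 3 (within the scatter), which stays within the scatter. Compound 1 and compound 2 also lie within the scatter of each other. The reader therefore expects no step beyond the scatter for compound 4, namely a number 1 percentage points higher from compound 2 to compound 4 (within the scatter). Compound 4 is estimated at 46%, between 32% and 60%.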

Compound 4, a percentage reported as inhibition, in the whole organism at one dose (the size of the read-out at that dose, not a potency): 53%
Compound 4: the middle estimate sits 7 percentage points below what was measured; the measured number falls inside the stated range.
By their numbers in this assay, from the lowest: compounds 1, 2, 4 and 3 (each within the scatter of the next, the first and the last beyond it).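

On a saturated chain carbon, four bonds along the chain from a carbonyl carbon, the position also tolerates a change that lengthens the carbon chain of the group while its count of fluorine atoms stays the same. In this assay, 2,2,3,3,3-pentafluoropropyl in place of 1,1,2,2,2-pentafluoroethyl leaves the read-out within the scatter (a number 8 percentage points higher from compound 2 to compound 4 (within the scatter)). Nothing shown accounts for this result. Still open, as far as these compounds go, is whether 3,3,4,4,4-pentafluorobutyl or an unfluorinated pentyl chain at this place would give a step beyond the scatter.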